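The compounds below may be only part of what the source reports. "The series", "measured", "known", "first", "only" and "open" are said of these compounds alone.

Of the compounds shown here, three that share one core have been tested in an ADME assay on THP-1 cells (Homo sapiens) for cytotoxicity; on this read-out higher numbers stand for lower toxicity in this test and lower numbers for higher toxicity in this test. Compound 1 `CN(C)CCNc1c(-c2ccccn2)nc2ccccn12` gives > 50000 nM, which is a limit of the assay rather than a number. Compound 2 `c1ccc(CNc2c(-c3ccccn3)nc3ccccn23)cc1` likewise gives > 50000 nM, again a limit. Among the measured compounds shown here, compound 3 `c1ccc(Nc2c(-c3ccccn3)nc3ccccn23)cc1` gives 6690 nM, the only number among the three, while the other two readings sit at the limit of > 50000 nM in this assay, at which 2 of the 3 values shown sit. From this it follows that there is an at least 7.4-fold lower number from compound 1 to compound 3 (0.87 log units; beyond the scatter) and an at least 7.4-fold lower number from compound 2 to compound 3 (0.87 log units; beyond the scatter), both beyond the scatter, so compound 3 is the one whose toxicity can actually be read. Compound 4 `COc1ccccc1Nc1c(-c2ccccn2)nc2ccccn12` differs from compound 3 by methoxy in place of hydrogen on an aromatic carbon. For the measured compounds named here, none of the measured steps touches a group on the phenyl itself; each exchanges the whole substituent on the nitrogen of the core, so they give no guide to the size of this smaller change. The step of a 1.1-fold lower number from compound 3 to compound 4 (0.05 log units; within the scatter) is therefore expected to stay within the scatter. Compound 4 is expected to give about 6000 nM, in a range from 2500 nM to 16000 nM.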

Compound 4, half-maximal cytotoxic concentration: > 50000 nM
Compound 4 gave a limit, no number (the forecaster's own chance of this, stated with the estimate: 10%); at least 8.3-fold (0.92 log units) between middle value and limit.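

Placing a methoxy group on the phenyl of compound 3, ortho to a large group, changes the result in this assay, with an at least 7.4-fold higher number from compound 3 to compound 4 (0.87 log units; beyond the scatter). The earlier steps shown here each exchanged the whole substituent on the nitrogen, whereas this one shows that a change on the aromatic ring alone can also move the read-out beyond the scatter. The value of compound 4 is a limit, not a number, so the full size of this step stays unknown, and compound 3 remains the only compound with a number: the limit of > 50000 nM in this assay, at which 3 of the 4 values shown sit.

The steps from compound 1 and from compound 2 to compound 4 join two limits and cannot be read. On these data alone, whether a smaller or larger group on the same carbon, such as fluorine, hydroxyl or an amine, would give the same result remains open.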